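A few compounds are considered here, and "the series" means these few. Any claim that something is new, unique, unknown or untested is made for them only; others in the source may bear on it.

Working notes on the series in an in vivo ADME assay on the whole organism for pharmacokinetics, with Mus musculus as the target, with a stated time of 8 h, at a dose of 200 mg/kg by the intraperitoneal route; a lower number here means that the compound disappears faster, a higher number that the compound lasts longer. Compound 1 `COc1ccc(C2=C(c3ccc(SC)cc3)CC3CCCN3C2=O)cc1OC` gives 7.29 h and compound 2 `CSc1ccc(C2=C(c3ccc(C)cc3)C(=O)N3CCCC3C2)cc1` gives 6.24 h, so compound 2 stands within the scatter of compound 1. Compound 3 `CSc1ccc(C2=C(c3ccc(C(F)(F)F)cc3)C(=O)N3CCCC3C2)cc1` differs from compound 2 by trifluoromethyl in place of methyl on an aromatic carbon, para to a large group: trifluoromethyl in place of methyl on an aromatic carbon. Within the data shown here, no measured pair shows this change, so the data give no direction, and no shift beyond the scatter is expected in this assay. The expected step is a 1.0-fold higher number from compound 2 to compound 3 (0.02 log units; within the scatter). For compound 3 the estimate is 6.5 h, with an expected range of 3.3 h to 12 h.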

Compound 3, half-life: 2.66 h
Compound 3: the middle estimate sits 2.4-fold (0.39 log units) above what was measured; measured number below the stated range.
By their numbers in this assay, from the lowest: compound 3; then compounds 2 and 1 (each within the scatter of the next).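

In this assay, trifluoromethyl in place of methyl on an aromatic carbon, para to a large group, gives a 2.3-fold lower number from compound 2 to compound 3 (0.37 log units; beyond the scatter) and so shows that half-life responds to the group at this position. Among these compounds, this is the first readable step, and it points toward faster disappearance, though it rests on one pair. The notes hold no measurement that bears on the cause of this step.

A fluorine, a methoxy group or an amine at this position could show whether the lower number is specific to trifluoromethyl. As far as these compounds go, whether the same change gives a similar step on another compound also stays open.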